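Adding a Chlorine to a Distant Ring

This account rests on a few compounds, and the source may have more. Where it says the series, first, only, none or still open, it means among the compounds named here.

The measured compounds and their values:
Compound 1, `O=C(O)C(=O)CC(=O)c1ccccc1Cl`: 3510 nM
Compound 2, `O=C(O)C(=O)CC(=O)c1c(Cl)cccc1Cl`: 37900 nM
Compound 3, `O=C(O)C(=O)CC(=O)c1ccc(-c2ccccc2)o1`: 1660 nM

All three were tested in an assay on isolated protein for inhibition of Flap endonuclease 1 (Homo sapiens); a higher number here means a weaker inhibitor, a lower number a stronger inhibitor. Among the compounds with values here, compound 1 and compound 2 share a core, and the single change between them is chloro in place of hydrogen on an aromatic carbon. That change made the step of an 11-fold higher number from compound 1 to compound 2 (1.03 log units; beyond the scatter), so the number rose sharply when the extra chlorine was introduced.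

Compound 3 has a different core, and the difference between the two cores is not broken down here. Its value is the lowest of the three numbers, and it lies closest to compound 1.

Compound 4, `O=C(O)C(=O)CC(=O)c1ccc(-c2ccc(Cl)cc2)o1`, has not yet been measured. It differs from compound 3 by chloro in place of hydrogen on an aromatic carbon. Within the data shown here, this is the same kind of change as the one from compound 1 to compound 2, but not the same: in the earlier pair the entering chloro group sat ortho to a group of 8 heavy atoms and meta to a chloro group, whereas in compound 4 it sits para to a large group, on a ring that carries no other substituent.

Among the measured compounds shown here, the earlier step gives the only direct guide, but its surroundings differ, so a step of similar size cannot be taken for granted. Compound 4 is expected to show a 1.5-fold higher number from compound 3 to compound 4 (0.18 log units; within the scatter), a smaller shift than the one seen before. The estimate for compound 4 in this assay is 2500 nM, with a likely range from 700 nM to 9000 nM.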

Compound 4, half-maximal inhibitory concentration: 10800 nM
The estimate for compound 4 lay 4.3-fold (0.64 log units) below the measured number; the whole stated range lies below it.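

In this assay, putting chloro in place of hydrogen on compound 3 gave a 6.5-fold higher number from compound 3 to compound 4 (0.81 log units; beyond the scatter), so compound 4 is a weaker inhibitor than compound 3, even with the chlorine para to a large group. The same change raised the number on both cores, and the two steps cannot be told apart in size: the same change on two cores in this assay, an 11-fold higher number (1.03 log units; beyond the scatter) from compound 1 to compound 2 and a 6.5-fold higher number (0.81 log units; beyond the scatter) from compound 3 to compound 4, 1.7-fold (0.22 log units) apart, within the scatter of two such steps

Within these two pairs, then, the change carried over from one core to the other with its direction and approximate size intact, but two pairs do not make a rule, and they do not explain why the number rises or show that the same would happen on a further core.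

The compounds shown leave open whether this rise is specific to chlorine or would also appear with another small group in the same place, such as fluoro, methyl or methoxy. They also leave open whether a group of a different kind there, such as an amine or a carboxylic acid, would move the number the other way and give a stronger inhibitor than compound 3.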